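Notes on chain lengthening across four related compounds

The source may report more compounds than this note shows. Statements on the series, on what has been measured and on what is new or still open speak of the compounds shown alone.

Measured so far:
compound 1, `CCCCCOC(=O)CCC(=O)N1CCN(CCCOc2cc3c(Nc4ccc(F)c(Cl)c4)ncnc3cc2OC)CC1`, gives 18.2% in a functional assay on A549 cells (Homo sapiens) for cytotoxicity, read by MTT assay, with a stated time of 24 h, tested at 80 uM; a higher number here means a weaker effect of the compound at the concentration tested, a lower number a stronger effect;
compound 2, `CCCCCCOC(=O)CCC(=O)N1CCN(CCCOc2cc3c(Nc4ccc(F)c(Cl)c4)ncnc3cc2OC)CC1`, gives 42.9% in this assay;
compound 3, `CCCCCCCCOC(=O)CCC(=O)N1CCN(CCCOc2cc3c(Nc4ccc(F)c(Cl)c4)ncnc3cc2OC)CC1`, gives 21.7% in this assay.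

The three share one core and differ only in the length of the saturated chain. Compound 1 to compound 2 is methyl in place of hydrogen on a saturated chain carbon, five bonds along the chain from an oxygen next to a carbonyl group, and the read-out moves by a number 24.7 percentage points higher from compound 1 to compound 2 (beyond the scatter). Further lengthening gives a number 21.2 percentage points lower from compound 2 to compound 3 (beyond the scatter), so that the overall change a number 3.5 percentage points higher from compound 1 to compound 3 (within the scatter) is small. The cores of compound 1 and compound 3 differ by propyl in place of hydrogen on a saturated chain carbon, five bonds along the chain from an oxygen next to a carbonyl group.

Compound 4, `CCCCCCCCCOC(=O)CCC(=O)N1CCN(CCCOc2cc3c(Nc4ccc(F)c(Cl)c4)ncnc3cc2OC)CC1`, is not yet measured. It differs from compound 3 by methyl in place of hydrogen on a saturated chain carbon, eight bonds along the chain from an oxygen next to a carbonyl group. This is the same kind of change as from compound 1 to compound 2, but the place is eight bonds along the chain from an oxygen next to a carbonyl group rather than five bonds along the chain. One added carbon has not moved the read-out in one direction so far. Compound 4 is expected at 28%, with a range from 12% to 48%, meaning an expected step of a number 6.3 percentage points higher from compound 3 to compound 4 (within the scatter). This rests on a number 3.5 percentage points higher from compound 1 to compound 3 (within the scatter) lying within the scatter, with compound 2 alone standing apart at 42.9%.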

Compound 4, a percentage reported as activity, at one concentration (the size of the read-out at that concentration, not a potency): 7.8%
The estimate for compound 4 lay 20.2 percentage points above the measured number; measured number outside the range, below it.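

One added carbon on the saturated chain does not carry from one core to another in this assay, where the new step gives a number 13.9 percentage points lower from compound 3 to compound 4 (beyond the scatter), opposite in direction to the earlier one: the same change on two cores in this assay, a number 24.7 percentage points higher (beyond the scatter) from compound 1 to compound 2 and a number 13.9 percentage points lower (beyond the scatter) from compound 3 to compound 4, 38.6 percentage points apart, beyond the scatter of two such steps

The longer extension also depends on the core, with a number 35.1 percentage points lower from compound 2 to compound 4 (beyond the scatter) set against the earlier step: the same change on two cores in this assay, a number 3.5 percentage points higher (within the scatter) from compound 1 to compound 3 and a number 35.1 percentage points lower (beyond the scatter) from compound 2 to compound 4, 38.6 percentage points apart, beyond the scatter of two such steps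

Across the series, the read-out gives a number 10.4 percentage points lower from compound 1 to compound 4 (beyond the scatter), which leaves compound 4 with the strongest effect of the four at the concentration tested, but no steady trend with chain length is shown, as compound 2 goes against one, and these values do not show what underlies the differing steps.

Going by these compounds, whether a longer chain than that of compound 4 would hold this strong effect or reverse it, as the read-out did between neighbouring chain lengths earlier, remains open. Also open, on these data alone, is how a branched chain, an amine or a carboxylic acid in place of the saturated chain would read on the shared core.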